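Chlorophenylsulfonyl replaces methyl-oxolane on an aryl nitrogen

The source may report more compounds than this note shows. Statements on the series, on what has been measured and on what is new or still open speak of the compounds shown alone.

Compound 2, `COc1ccc([C@H]2CC(=O)N(c3cccc(NCC4CCOC4)c3)C2)cc1OC1CCCC1`: > 10000 nM
Compound 1, `COc1ccc([C@H]2CC(=O)N(Cc3cccc(N)c3)C2)cc1OC1CCCC1`: > 10000 nM

Both results in a functional assay on HEK293 cells (Homo sapiens) for cytotoxicity (on this read-out lower numbers stand for higher toxicity in this test and higher numbers for lower toxicity in this test), are limits of the assay rather than measured numbers. Compound 2 stands at that limit with > 10000 nM. Compound 1 likewise gives only a limit, > 10000 nM. The two measured compounds therefore share one position: the limit of > 10000 nM in this assay, at which 2 of the 2 values shown sit.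

Compound 3, `COc1ccc([C@H]2CC(=O)N(c3cccc(NS(=O)(=O)c4cccc(Cl)c4)c3)C2)cc1OC1CCCC1`, is still to be tested in this assay. It differs from compound 2 in one place, ((3-chlorophenyl)sulfonyl in place of (oxolan-3-yl)methyl on a nitrogen on an aromatic ring). Going by the values given here, no step between measured compounds is known, so the size of any shift cannot be read from a precedent, and the two limits give no sign that this change would bring the series into the measurable range. The expected step is a number no higher from compound 2 to compound 3 (the limit leaves the size open), no change beyond the scatter. Compound 3 is accordingly estimated at 10000 nM, within 5000 nM to 30000 nM, most probably reported once more as a limit.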

Compound 3, half-maximal cytotoxic concentration: > 10000 nM
Compound 3 gave a limit, no number; the forecaster's own chance of this, stated with the estimate: 70%; the middle value sits exactly at the limit.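

Compound 2 and compound 3 each give only a limit, so no step between them can be read: the limit of > 10000 nM in this assay, at which 3 of the 3 values shown sit.

The compounds shown leave open how (3-chlorophenyl)sulfonyl and (oxolan-3-yl)methyl compare in this assay, and whether any compound of this series gives a measurable value there.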